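Furan for Bromophenyl in Acetyl Pyrazolines: Cytotoxicity

A few compounds are considered here, and "the series" means these few. Any claim that something is new, unique, unknown or untested is made for them only; others in the source may bear on it.

Compound 1 `COc1cc(C2CC(c3ccc(Br)cc3)=NN2C(C)=O)cc(OC)c1OC`: 4780 nM
Compound 2 `CC(=O)N1N=C(c2ccc(Br)cc2)CC1c1cccc(Cl)c1Cl`: 39800 nM
Compound 3 `COc1cc(C2CC(c3ccco3)=NN2C(C)=O)cc(OC)c1OC`: 10900 nM

These three compounds were tested in a functional assay on OVCAR cells (Homo sapiens) for cytotoxicity, read by sulforhodamine B assay, with a stated time of 48 h; a higher number here means a weaker inhibitor, a lower number a stronger inhibitor. Compound 3 differs from compound 1 by furan-2-yl in place of 4-bromophenyl on a carbon with a double bond to nitrogen, and the resulting step is a 2.3-fold higher number from compound 1 to compound 3 (0.36 log units; beyond the scatter). The difference between the cores of compound 1 and compound 2 is not broken down here; compound 2 gives the highest number of the three.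

Compound 4 `CC(=O)N1N=C(c2ccco2)CC1c1cccc(Cl)c1Cl` has not been measured. It differs from compound 2 by furan-2-yl in place of 4-bromophenyl on a carbon with a double bond to nitrogen. This is the same kind of change as from compound 1 to compound 3, but around the place the ring atom two ring bonds away bears a group of 8 heavy atoms in compound 2, whereas in compound 1 it bears a large group. A step of similar size is expected, a 2.3-fold higher number from compound 2 to compound 4 (0.35 log units; beyond the scatter), because the earlier step of a 2.3-fold higher number from compound 1 to compound 3 (0.36 log units; beyond the scatter) was modest. Compound 4 is therefore expected near 90000 nM, most likely between 35000 nM and 250000 nM.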

Compound 4, half-maximal inhibitory concentration: 81200 nM
Compound 4: middle estimate off by 1.1-fold (0.04 log units), on the high side; low and high end bracket the measured number.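

In this assay, furan-2-yl in place of 4-bromophenyl gives a 2.0-fold higher number from compound 2 to compound 4 (0.31 log units; beyond the scatter), so on the core of compound 2 the change again leaves a weaker inhibitor. The step carries over between the two cores with little change in size: the same change on two cores in this assay, a 2.3-fold higher number (0.36 log units; beyond the scatter) from compound 1 to compound 3 and a 2.0-fold higher number (0.31 log units; beyond the scatter) from compound 2 to compound 4, 1.1-fold (0.05 log units) apart, within the scatter of two such steps. This holds for these two cores alone, and it shows neither why the step has this size nor that it would keep it on a third core.

The compounds shown leave open how an amine or a carboxylic acid in place of furan-2-yl would compare. They also leave open whether the step would persist with a longer chain in place of the acetyl group.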